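This account rests on a few compounds, and the source may have more. Where it says the series, first, only, none or still open, it means among the compounds named here.

Measured compounds:

Compound 1 `C[S+]([O-])/C=C/c1cc(=O)c2cc(Cl)ccc2o1` gives 6500 nM in a functional assay on DLD-1 cells (Homo sapiens) for cytotoxicity, with a stated time of 48 h; on this read-out higher numbers stand for weaker inhibition and lower numbers for stronger inhibition.
Compound 2 `CC(C)CCOc1ccc2oc(/C=C/[S+](C)[O-])cc(=O)c2c1` gives 4100 nM.
Compound 3 `CC(C)Oc1ccc2oc(/C=C/[S+](C)[O-])cc(=O)c2c1` gives 8000 nM.

Compound 3 stands highest of the three numbers, yet neither of its neighbours is separated from it beyond the scatter: a 1.2-fold higher number from compound 1 to compound 3 (0.09 log units; within the scatter), and a 2.0-fold higher number from compound 2 to compound 3 (0.29 log units; within the scatter). Compound 1 and compound 2 likewise sit close together, a 1.6-fold lower number from compound 1 to compound 2 (0.20 log units; within the scatter). All three steps change the same place, the substituent on the aromatic ring, and none of them moves the number beyond the scatter.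

Compound 4 `C[S+]([O-])/C=C/c1cc(=O)c2cc(OC(=O)C(C)(C)C)ccc2o1` is the next member. (tert-butyl)carbonyl in place of isopropyl on an oxygen on an aromatic ring The three measured steps are the ones that bear on this change, since each swaps a group at that same place, and each stayed within the scatter. On that basis no step beyond the scatter is expected in this assay from compound 3 to compound 4, though the wide range allows either direction. Compound 4 is therefore estimated at 7000 nM, with a range from 3000 nM to 16000 nM, an expected step of a 1.1-fold lower number from compound 3 to compound 4 (0.06 log units; within the scatter).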

Compound 4, half-maximal inhibitory concentration: 8000 nM
The estimate for compound 4 lay 1.1-fold (0.06 log units) below the measured number; low and high end bracket the measured number.
By their numbers in this assay, from the lowest: compounds 2, 1, 3 and 4 (each within the scatter of the next).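

In this assay, the step from an alkyl to an acyl group on this oxygen, which brings in a carbonyl and a hydrogen-bond acceptor, leaves the number in place (no change at the digits printed from compound 3 to compound 4 (within the scatter)). The comparisons with the isopentyl ether (a 2.0-fold higher number from compound 2 to compound 4 (0.29 log units; within the scatter)) and with the chloro compound (a 1.2-fold higher number from compound 1 to compound 4 (0.09 log units; within the scatter)) also stay within the scatter, so all four compounds, including the newly added ((tert-butyl)carbonyl)oxy group, lie within the scatter of the next in this series. No measurement shown here offers an explanation for this result.

Going by these compounds, whether an amine or a carboxylic acid on this aromatic carbon would move the number beyond the scatter remains open. So does whether a change elsewhere on the shared core would have a larger effect than any of the changes seen at this place.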